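The source may report more compounds than this note shows. Statements on the series, on what has been measured and on what is new or still open speak of the compounds shown alone.

Measured so far in an ADME assay on HFF cells (Homo sapiens) for cytotoxicity, read by MTT assay, with a stated time of 72 h; a higher number here means a weaker inhibitor, a lower number a stronger inhibitor:
Compound 1 `O=C1O[C@H]([C@@H](O)Cn2cc(-c3ccc(Br)cc3)nn2)C(OCc2ccccc2)=C1OCc1ccccc1` gives 5100 nM.
Compound 2 `O=C1O/C(=C\Cn2cc(-c3cc(F)cc(F)c3)nn2)C(OCc2ccccc2)=C1OCc1ccccc1` reaches only a limit of the assay, > 100000 nM.
Compound 3 `COc1ccc(-c2cn(C/C=C3\OC(=O)C(OCc4ccccc4)=C3OCc3ccccc3)nn2)cc1` likewise reaches only a limit of the assay, > 100000 nM.

Going by the values given here, compound 1 is therefore the one compound here with an actual number; the other two sit at the limit of > 100000 nM in this assay, at which 2 of the 3 values shown sit. Among the compounds with values here, the one change measured between two compounds, a step that the two limits leave unreadable from compound 2 to compound 3, is unreadable in size, since both ends are limits, and it exchanges one aromatic group for another rather than for a chain.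

The compound still to be measured is compound 4 `CCCCCCCCCCc1cn(C[C@H](O)[C@H]2OC(=O)C(OCc3ccccc3)=C2OCc2ccccc2)nn1`, which differs from compound 1 in one place: decyl in place of 4-bromophenyl on an aromatic carbon. Within the data shown here, no measured step describes what a chain of this kind does in this assay, and the one recorded step gives no size at all. The expectation for compound 4 therefore rests on compound 1 alone, with a wide band around it.

Compound 4 is thus estimated at 5000 nM, between 1000 nM and 30000 nM, which would mean an expected step of a 1.0-fold lower number from compound 1 to compound 4 (0.01 log units; within the scatter) in this assay, not clearly beyond the scatter in either direction.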

Compound 4, half-maximal inhibitory concentration: > 100000 nM
Compound 4: only a limit was reported (the forecaster's own chance of this, stated with the estimate: 20%); middle value at least 20-fold (1.30 log units) away from the limit.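

Going by these compounds alone, exchanging 4-bromophenyl for decyl on this aromatic carbon gives an at least 19-fold higher number from compound 1 to compound 4 (1.29 log units; beyond the scatter) in this assay and is the first step in this set with a readable size. Compound 4 gives > 100000 nM and this is a limit of the assay, not a number, so the printed size is only a minimum. Among the compounds shown, the group at this position can therefore separate a measurable value from the limit, and compound 1 is left alone with an actual number: the limit of > 100000 nM in this assay, at which 3 of the 4 values shown sit.

As far as these compounds go, how a shorter chain such as hexyl or a longer chain such as dodecyl would read at this position remains open. Also open, from the compounds shown here alone, is whether a plain phenyl or 4-chlorophenyl group would keep a measurable value, which would help show whether the ring or the bromine goes with the number for compound 1.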